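The source may report more compounds than this note shows. Statements on the series, on what has been measured and on what is new or still open speak of the compounds shown alone.

Measured so far in a functional assay on THP-1 cells (Homo sapiens) for cytotoxicity, read by MTT assay, with a stated time of 48 h; a lower number here means a stronger inhibitor, a higher number a weaker inhibitor:
- compound 1, `Fc1ccc2nc(NC(=S)Nc3ccc(Cl)cc3)sc2c1`: 31200 nM
- compound 2, `Cc1ccc2nc(NC(=S)Nc3ccccc3)sc2c1`: > 50000 nM, which is a limit of the assay and not a number
- compound 3, `Cc1ccc2nc(NC(=S)Nc3ccc(F)cc3)sc2c1`: 36900 nM

Compound 2 therefore stands at the limit of > 50000 nM in this assay, at which 1 of the 3 values shown sits; its position relative to compounds 1 and 3 cannot be fixed from a limit.

Compound 4, `CCOc1ccc2nc(NC(=S)Nc3ccccc3)sc2c1`, has not been measured. Relative to compound 2 the change is ethoxy in place of methyl on an aromatic carbon.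

Going by the values given here, no measured step involves this exchange. Among the compounds with values here, the sole single-point step, an at least 1.3-fold lower number from compound 2 to compound 3 (0.13 log units; that floor lies within the scatter), concerns a different change on the other ring and lies within scatter, so it offers no direction. For compound 4 the expected step is a number no higher from compound 2 to compound 4 (the limit leaves the size open), which is no step beyond scatter. Compound 4 is estimated at 50000 nM, range 25000 nM to 100000 nM, with a limit again likely.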

Compound 4, half-maximal inhibitory concentration: 43800 nM
Compound 4: the middle estimate sits 1.1-fold (0.06 log units) above what was measured, within the range that was stated.
By their numbers in this assay, from the lowest: compounds 1, 3 and 4 (each within the scatter of the next). At a limit, above all of these: compound 2.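

Ethoxy in place of methyl at this position gives an at least 1.1-fold lower number from compound 2 to compound 4 (0.05 log units; that floor lies within the scatter) in this assay. Going by these compounds alone, compound 4 gives 43800 nM, so this position now has a measured number with no substituent on the other ring, which the earlier compounds did not provide. Compound 2 is a limit and not a number, so the true size of this step stays open: the limit of > 50000 nM in this assay, at which 1 of the 4 values shown sits.

The compounds shown leave open whether an amine, a carboxylic acid or a longer alkoxy chain such as butoxy at this position would move the number beyond the scatter. Also open, going by these compounds, is how ethoxy behaves with fluoro or chloro on the other ring.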